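The compounds below may be only part of what the source reports. "The series", "measured", "known", "first", "only" and "open" are said of these compounds alone.

Working notes on the series, read in a functional assay on L1210 cells (Mus musculus) for antiproliferative activity; a higher number here means a weaker inhibitor, a lower number a stronger inhibitor. For the measured compounds named here, compound 3 `COc1cc(C(=O)c2sc(-c3ccc(I)cc3)cc2N)cc(OC)c1OC` gives 400 nM, the higher of the two true numbers so far. Its nearest neighbour is compound 2 `COc1cc(C(=O)c2sc(-c3ccc(Br)cc3)cc2N)cc(OC)c1OC`, which gives 100 nM. Compound 1 `COc1cc(C(=O)c2sc(-c3ccc(-c4ccccc4)cc3)cc2N)cc(OC)c1OC` gives > 10000 nM, and this is a limit of the assay, not a number.

The next entry is compound 4 `COc1cc(C(=O)c2sc(-c3ccccc3)cc2N)cc(OC)c1OC`, reached by hydrogen in place of iodo on an aromatic carbon, which is hydrogen in place of iodo on an aromatic carbon. Three measured steps change this same substituent. The two away from phenyl are large: an at least 100-fold lower number from compound 1 to compound 2 (2.00 log units; beyond the scatter) and an at least 25-fold lower number from compound 1 to compound 3 (1.39 log units; beyond the scatter). On these data alone, both rest on the limit of compound 1, so their true sizes remain open. The closest guide is the halogen swap, which is modest: a 4.0-fold higher number from compound 2 to compound 3 (0.60 log units; beyond the scatter). Going by the values given here, no measured compound carries hydrogen here, so that swap can be carried over only loosely.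

In this assay, a modest step towards a lower number is expected, and a result within the scatter of compound 3 would be unsurprising. The expected change is a 1.6-fold lower number from compound 3 to compound 4 (0.20 log units; within the scatter). The estimated value for compound 4 is 250 nM, with an expected range of 60 nM to 1000 nM.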

Compound 4, half-maximal inhibitory concentration: 11 nM
Compound 4: the middle estimate sits 23-fold (1.36 log units) above what was measured; the whole stated range lies above it.
By their numbers in this assay, from the lowest: compound 4; then compound 2; then compound 3. At a limit, above all of these: compound 1.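

In this assay, for the compounds shown here, the change from 4-iodophenyl to phenyl is the first step at this carbon that leaves the ring with hydrogen alone, and it gives a 36-fold lower number from compound 3 to compound 4 (1.56 log units; beyond the scatter), while the matching change from bromo gives a 9.1-fold lower number from compound 2 to compound 4 (0.96 log units; beyond the scatter). Compound 4 therefore holds the lowest number of the four, so neither halogen nor phenyl improves on hydrogen here, and the gap between the two halogens turns out smaller than the gap from either of them to hydrogen. The widest step, an at least 900-fold lower number from compound 1 to compound 4 (2.95 log units; beyond the scatter), starts from a limit and not a number, so its true size stays open: the limit of > 10000 nM in this assay, at which 1 of the 4 values shown sits.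

The compounds shown leave open whether any group at this carbon can match hydrogen, or whether the loss belongs to halogens and phenyl alone; fluoro, methyl or methoxy would test this more directly than a further large group. They also leave open whether the same ranking holds with a group such as an amine or a hydroxyl at this carbon, since only one place on the shared core varies across the four compounds.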